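This account rests on a few compounds, and the source may have more. Where it says the series, first, only, none or still open, it means among the compounds named here.

Measured so far:
compound 1, `Cc1ccc(NC(=O)c2c(O)c3cccnc3n(-c3ccccc3)c2=O)cc1`, -3.5%
compound 2, `COc1ccc(NC(=O)c2c(O)c3cccnc3n(-c3ccccc3)c2=O)cc1`, 0.3%
compound 3, `Cc1cccc(NC(=O)c2c(O)c3cccnc3n(-c3ccccc3)c2=O)c1`, 14.2%

In a functional assay on the whole organism for inhibition, with Rattus norvegicus as the target, read by paw edema, at a dose of 100 mg/kg by the oral route (on this read-out lower numbers stand for less inhibition and higher numbers for more inhibition at the one dose given (going by the name of the read-out)), compound 3 stands highest of the three numbers; the nearest is a number 13.9 percentage points higher from compound 2 to compound 3 (beyond the scatter) and the furthest a number 17.7 percentage points higher from compound 1 to compound 3 (beyond the scatter). Compound 4, `COc1ccc(NC(=O)c2c(O)c3cccnc3n(-c3ccccc3)c2=O)cn1`, differs from compound 3 by 6-methoxypyridin-3-yl in place of 3-methylphenyl on an amide-type nitrogen. Two earlier steps bear on this. Methoxy in place of methyl on an aromatic carbon left the read-out unchanged, a number 3.8 percentage points higher from compound 1 to compound 2 (within the scatter). Moving from a 4-methoxyphenyl to a 3-methylphenyl on the amide-type nitrogen gave a modest rise, a number 13.9 percentage points higher from compound 2 to compound 3 (beyond the scatter). Compound 4 carries a methoxy-bearing ring again rather than a 3-methylphenyl, so a fall back toward the level of compound 2 is expected, a number 11.2 percentage points lower from compound 3 to compound 4 (beyond the scatter). Compound 4 is estimated at 3%, between -12% and 16%. Among the compounds with values here, the ring nitrogen that enters has no counterpart among the measured compounds, which widens the range.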

Compound 4, a percentage reported as inhibition, in the whole organism at one dose (the size of the read-out at that dose, not a potency): 13.1%
The estimate for compound 4 lay 10.1 percentage points below the measured number; low and high end bracket the measured number.
By their numbers in this assay, from the lowest: compounds 1 and 2 (each within the scatter of the next); then compounds 4 and 3 (each within the scatter of the next).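

In this assay, a methoxy-bearing ring on the amide-type nitrogen need not keep the read-out low: 6-methoxypyridin-3-yl in place of 3-methylphenyl leaves it level (a number 1.1 percentage points lower from compound 3 to compound 4 (within the scatter)). Compared with 4-methoxyphenyl, the same group gives a modest rise (a number 12.8 percentage points higher from compound 2 to compound 4 (beyond the scatter)), and the change from 4-methylphenyl points the same way (a number 16.6 percentage points higher from compound 1 to compound 4 (beyond the scatter)). Nothing at hand accounts for these steps.

Still open, going by these compounds, is whether an amine or a carboxylic acid in place of the methoxy of 6-methoxypyridin-3-yl would hold this level. A longer chain there is equally untested in the compounds shown.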